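This account rests on a few compounds, and the source may have more. Where it says the series, first, only, none or still open, it means among the compounds named here.

Measured so far:
- compound 1 `CC1=CC[C@H](C(C)C)c2cc(C)c(OC(=O)c3ccc([N+](=O)[O-])cc3)cc21`: 16.8%
- compound 2 `Cc1cc2c(C(C)C)ccc(C)c2cc1OC(=O)c1ccc([N+](=O)[O-])cc1`: 100%

Two compounds of the series have numbers in a functional assay on U-251 cells (Homo sapiens) for antiproliferative activity, read by sulforhodamine B assay, with a stated time of 48 h, tested at 50 uM; on this read-out higher numbers stand for more inhibition at the one concentration tested (going by the name of the read-out) and lower numbers for less inhibition. Compound 1 gives 16.8% and stands lowest of the two. Going by the values given here, its nearest neighbour is compound 2, which in this assay gives 100%, a gap that lies beyond the scatter; compound 2 carries a different core and no single-point step between the two is recorded, so the pair shows only that compound 2 reaches the higher number.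

Compound 3 `COc1ccc(C(=O)Oc2cc3c(cc2C)[C@@H](C(C)C)CC=C3C)cc1` keeps the core of compound 1 and differs in one place: methoxy in place of nitro on an aromatic carbon. The nitro leaves, a methoxy enters, on an aromatic carbon of the six-membered aromatic ring of carbon only; cut one bond further out, 4-nitrophenyl becomes 4-methoxyphenyl.

Among the compounds with values here, no measured pair shows what this exchange does in this assay, so the size of the step is uncertain; the expectation is a step of no more than the scatter, if anything a slight move downward, as compound 1 already sits near the low end. Compound 3 is therefore expected to give 14% in this assay, between 0% and 42%, which amounts to an expected step of a number 2.8 percentage points lower from compound 1 to compound 3 (within the scatter).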

Compound 3, a percentage reported as inhibition, at one concentration (the size of the read-out at that concentration, not a potency): 37%
Beside the measured number, compound 3's estimate is 23 percentage points below it; measured number inside the range.
By their numbers in this assay, from the lowest: compound 1; then compound 3; then compound 2.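

On the core of compound 1, the aromatic carbon para to a large group is sensitive to what it carries: in this assay, methoxy in place of nitro gives a number 20.2 percentage points higher from compound 1 to compound 3 (beyond the scatter). Going by these compounds alone, this is the first single-place pair, so it is the first reading of a change at this position rather than a difference between compounds that also differ in their cores. The 4-nitrophenyl group is therefore not required for the inhibition seen on this core, and within this pair the 4-methoxyphenyl group gives the higher number, although one modest step sets no trend. Nothing at hand ties this step to any property of either group.

One pair cannot say whether the upward move comes from the arrival of methoxy or the departure of nitro; a plain hydrogen, an amine or a carboxylic acid at the same aromatic carbon would help separate the two readings. As far as these compounds go, whether the same exchange moves the number in the same direction on the core of compound 2 also stays open.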